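This account rests on a few compounds, and the source may have more. Where it says the series, first, only, none or still open, it means among the compounds named here.

Series notes, step from compound 2 to compound 3.

Going by the values given here, compound 2 `CC(C)OC(=O)N1CCC(Oc2ncnc3c2CCN3c2ccc([S+]([O-])N(C)C)cc2)CC1` stands highest of the two numbers so far in a functional assay on CHO-K1 cells with Glucose-dependent insulinotropic receptor (Homo sapiens) as the target, read by a luciferase reporter, with a stated time of 5 h (a higher number here means a larger maximal response, a lower number a smaller maximal response), where compound 2 gives 128%. Among the compounds with values here, its only measured neighbour is compound 1 `CC(C)OC(=O)N1CCC(Oc2ncnc3c2CCN3c2ccc(S(C)(=O)=O)nc2)CC1`, which in this assay gives 97%; the step of a number 31 percentage points higher from compound 1 to compound 2 (beyond the scatter) is the single change seen so far at this position, and it is large.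

Compound 3 `CC(C)OC(=O)N1CCC(Oc2ncnc3c2CCN3c2ccc([S@@+](C)[O-])c(F)c2)CC1` differs from compound 2 in the same position: a group of 10 heavy atoms (7 carbon, 1 oxygen, 1 fluorine, 1 sulfur; one six-membered aromatic ring of carbon only) in place of a group of 11 heavy atoms (8 carbon, 1 nitrogen, 1 oxygen, 1 sulfur; one six-membered aromatic ring of carbon only), on a nitrogen on an aromatic ring in a ring. Within the data shown here, the only step that bears on it is the one from compound 1 to compound 2, which also swapped the group on that ring nitrogen; it showed that changes here can move the maximal response well beyond the scatter. Both compound 1 and compound 3 carry a sulfur-oxygen group on a carbon of the ring rather than the dimethylamino-bearing sulfur of compound 2, so a step back in the direction of compound 1 is the expectation, though smaller than the step from compound 1 to compound 2 and uncertain in size.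

The expected step for compound 3 in this assay is a number 18 percentage points lower from compound 2 to compound 3 (beyond the scatter), i.e. a moderate fall. Compound 3 is estimated at 110%, with a range from 88% to 135%.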

Compound 3, largest response reached (reported as percent of maximum), in percent of the reference or control that the assay uses: 155%
For compound 3 the middle estimate is 45 percentage points below the measured one, outside the stated range (above it).
By their numbers in this assay, from the lowest: compound 1; then compound 2; then compound 3.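

In this assay, the group on the nitrogen on an aromatic ring in a ring can lift the maximal response further without the dimethylamino-bearing sulfur of compound 2: the result is a number 27 percentage points higher from compound 2 to compound 3 (beyond the scatter), with the entering group carrying a methyl on sulfur and a fluorine on the carbon-only aromatic ring. Across the three compounds, the change at this one place now spans a number 58 percentage points higher from compound 1 to compound 3 (beyond the scatter), so the position has a wider reach than the first step alone showed. The step to compound 3 changes several things at once, including the loss of the nitrogen, the arrival of fluorine and a defined stereocentre, and its size cannot be assigned to any one of them.

On these data alone, what stays open is how much of the rise goes with the fluorine and how much with the methyl-bearing sulfur group and its configuration. A chlorine or a nitrile in place of the fluorine, or the opposite configuration at sulfur, would separate these contributions. No measurement here bears on the reason for the rise.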